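The source may report more compounds than this note shows. Statements on the series, on what has been measured and on what is new or still open speak of the compounds shown alone.

Compound 1 `CCC(C)(C)Cc1c[nH]c(CCc2ccc(-n3cccn3)cc2)n1` sits lowest of the three values in a functional assay on HEK293 cells for agonist activity at Bombesin receptor subtype-3 (Homo sapiens), read by luminescence and calcium flux, with a stated time of 10 min (a lower number here means that less compound is needed, a higher number that more compound is needed for the effect), where compound 1 gives 135 nM; compound 3 `CCC(C)(C)Cc1c[nH]c(CCc2ccc(-c3cccc(C#N)n3)cc2)n1` gives 193 nM and compound 2 `CCC(C)(C)Cc1c[nH]c(CCc2ccc(-c3cnccn3)cc2)n1` gives 431 nM. Compound 4 `CCC(C)(C)Cc1c[nH]c(CCc2ccc(-c3ccc(F)cn3)cc2)n1` is unmeasured; its change from compound 1 is 5-fluoropyridin-2-yl in place of 1H-pyrazol-1-yl on an aromatic carbon. Among the compounds with values here, two measured steps bear on this: a 1.4-fold higher number from compound 1 to compound 3 (0.16 log units; within the scatter), where a six-membered aromatic ring also entered in place of the pyrazolyl, stays within the scatter, whereas a 3.2-fold higher number from compound 1 to compound 2 (0.50 log units; beyond the scatter) lies beyond it; between those two, a 2.2-fold lower number from compound 2 to compound 3 (0.35 log units; beyond the scatter). The nearer precedent is compound 3, so only a small rise is expected for compound 4, a 1.5-fold higher number from compound 1 to compound 4 (0.17 log units; within the scatter), probably not clearly beyond the scatter. Compound 4 is therefore estimated at 200 nM, with a range of 90 nM to 500 nM.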

Compound 4, half-maximal effective concentration: 66 nM
Compound 4: the middle estimate sits 3.0-fold (0.48 log units) above what was measured, outside the stated range (below it).
By their numbers in this assay, from the lowest: compound 4; then compounds 1 and 3 (each within the scatter of the next); then compound 2.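

At this position, on an aromatic carbon para to a large group, a six-membered aromatic ring can lower the number: 5-fluoropyridin-2-yl gives a 2.0-fold lower number from compound 1 to compound 4 (0.31 log units; beyond the scatter), the first replacement of 1H-pyrazol-1-yl shown to do so beyond the scatter. The identity of the six-membered group also matters, with a 2.9-fold lower number from compound 3 to compound 4 (0.47 log units; beyond the scatter) and a 6.5-fold lower number from compound 2 to compound 4 (0.81 log units; beyond the scatter), leaving compound 4 lowest of the four. Nothing available explains these differences.

Still open, going by these compounds, is how plain pyridin-2-yl compares with 5-fluoropyridin-2-yl. Also open, on these data alone, is how an amine or a methoxy group would compare in place of the fluorine.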